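A few compounds are considered here, and "the series" means these few. Any claim that something is new, unique, unknown or untested is made for them only; others in the source may bear on it.

Measured in an in vivo ADME assay on the whole organism for pharmacokinetics, with Rattus norvegicus as the target; a lower number here means slower removal, a higher number faster removal of the compound:
- compound 1 `CCCS(=O)(=O)N1CCC(CNC(=O)C2CC2)(C(=O)N2CCOCC2)CC1`: 18 mL/min/kg
- compound 2 `CCCS(=O)(=O)N1CCC(CNC(=O)c2ccc(F)cc2C(F)(F)F)(C(=O)N2CCOCC2)CC1`: 18 mL/min/kg

On these numbers, compound 2 stands level with compound 1, its nearest neighbour. The next structure is compound 3 `CCCS(=O)(=O)N1CCC(CNC(=O)c2ccccc2OC(F)(F)F)(C(=O)N2CCOCC2)CC1`, which carries 2-(trifluoromethoxy)phenyl in place of 4-fluoro-2-(trifluoromethyl)phenyl on a carbonyl carbon. For the measured compounds named here, one measured step bears on this place, the exchange of cyclopropyl for 4-fluoro-2-(trifluoromethyl)phenyl on a carbonyl carbon, which showed no change at the digits printed from compound 1 to compound 2 (within the scatter). A single step is thin evidence, but it gives no reason to expect a shift beyond the scatter in this assay, and no direction can be argued from it. The expected result is a 1.1-fold higher number from compound 2 to compound 3 (0.05 log units; within the scatter). For compound 3 the estimated clearance is 20 mL/min/kg, with an expected range of 11 mL/min/kg to 34 mL/min/kg.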

Compound 3, clearance in the Rattus norvegicus assay: 18 mL/min/kg
For compound 3 the middle estimate is 1.1-fold (0.05 log units) above the measured one; measured number inside the range.
By their numbers in the Rattus norvegicus assay, from the lowest: compounds 1, 2 and 3 (each within the scatter of the next).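

In the Rattus norvegicus assay, the exchange of one substituted phenyl for another on this carbonyl carbon gives no change at the digits printed from compound 2 to compound 3 (within the scatter), and the exchange of cyclopropyl for 2-(trifluoromethoxy)phenyl gives no change at the digits printed from compound 1 to compound 3 (within the scatter). Across the three compounds shown, neither the loss of the 4-fluoro substituent, nor trifluoromethoxy in place of trifluoromethyl, nor the added hydrogen-bond acceptor separates compound 3 from the other two in clearance. In a physicochemical assay for lipophilicity (a lower number here means a more polar compound, a higher number a more lipophilic compound), compound 2 gives < 1.4, which is a limit of the assay. In the physicochemical assay compound 3 gives < 1.4, which is also a limit of the assay. In the physicochemical assay the step between compound 2 and compound 3 cannot be read, as both sit at a limit of the assay: the limit of < 1.4 in the physicochemical assay, at which 2 of the 2 values shown sit.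

Open, as far as these compounds go, is whether an amine, a carboxylic acid or a pyridine ring on this carbonyl carbon would move the clearance. Also open, from the compounds shown here alone, is whether a change elsewhere on the shared core, such as a longer chain on the sulfonyl group, would do so.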